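Ethoxy replacement at the cytotoxicity limit

The source may report more compounds than this note shows. Statements on the series, on what has been measured and on what is new or still open speak of the compounds shown alone.

Values from an ADME assay on Huh-7 cells (Homo sapiens) for cytotoxicity, with a stated time of 72 h (a lower number here means that less compound is tolerated, a higher number that more compound is tolerated), for the measured compounds:
- compound 1 `CCOc1cccc2c1S(=O)(=O)N=C2C1=C(O)[C@H](C(C)(C)C)N(CCC(C)(C)C)C1=O` gives > 33000 nM
- compound 2 `CCOc1cccc2c1S(=O)(=O)N=C2C1=C(O)[C@H](CC(C)C)N(CCC(C)(C)C)C1=O` gives > 33000 nM
- compound 3 `CCOc1cccc2c1S(=O)(=O)N=C2C1=C(O)[C@H](C(C)(C)C)N(CCC(C)C)C1=O` gives > 33000 nM

Compound 1 sits at > 33000 nM, which is a limit and not a number. Among the compounds with values here, the values of compound 2 and compound 3 are limits as well, so the series so far shows only (the limit of > 33000 nM in this assay, at which 3 of the 3 values shown sit).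

The next compound is compound 4 `CC(C)(C)CCN1C(=O)C(C2=NS(=O)(=O)c3c(CCS(C)(=O)=O)cccc32)=C(O)[C@@H]1C(C)(C)C`, which keeps the rest of compound 1 and carries the change (2-(methylsulfonyl)ethyl in place of ethoxy on an aromatic carbon). In words, this is 2-(methylsulfonyl)ethyl in place of ethoxy on an aromatic carbon.

Two measured steps are available, and neither touches the ethoxy group. One is a step that the two limits leave unreadable from compound 1 to compound 2, with isobutyl in place of tert-butyl on a saturated ring carbon. The other is a step that the two limits leave unreadable from compound 1 to compound 3, with hydrogen in place of methyl on a saturated chain carbon. Within the data shown here, neither has a readable size, so they give no measure for the new change and show only that these two changes leave the readings at the limit.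

No step beyond the scatter is expected in this assay, and a further limit is the likeliest report. The expected step is a number no higher from compound 1 to compound 4 (the limit leaves the size open), an estimate anchored on compound 1 at > 33000 nM and not on any measured number. The estimate for compound 4 is 33000 nM, with an expected range from 15000 nM to 60000 nM.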

Compound 4, half-maximal cytotoxic concentration: > 33000 nM
Compound 4: no number, only a limit; the forecaster's own chance of this, stated with the estimate: 85%; the middle value lies on the limit itself.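

In this assay compound 4 gives > 33000 nM, which is a limit and not a number. Compound 1 also reads as a limit, so no step can be read between compound 1 and compound 4. The compounds shown leave open how much compound any of them tolerates beyond this limit, and whether the ethoxy replacement changes that tolerance at all.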